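The source may report more compounds than this note shows. Statements on the series, on what has been measured and on what is new or still open speak of the compounds shown alone.

Compound 1 `CN1CCN(CCCCCCn2c3c(c4ccccc42)C(=O)c2c[n+]([O-])c4ccccc4c2C3=O)CC1` and compound 2 `CN(C)CCCCn1c2c(c3ccccc31)C(=O)c1c[n+]([O-])c3ccccc3c1C2=O` share one core and differ only in the basic amine at the end of the chain attached to the aromatic nitrogen. Among the measured compounds shown here, in a functional assay on HCT-116 cells (Homo sapiens) for cytotoxicity, read by MTT assay, with a stated time of 72 h (a higher number here means a weaker inhibitor, a lower number a stronger inhibitor), compound 1 gives 2900 nM, the higher of the two numbers measured so far, while compound 2 gives 450 nM. For the measured compounds named here, the single measured step runs a 6.4-fold lower number from compound 1 to compound 2 (0.81 log units; beyond the scatter).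

Compound 3 `CN(C)CCCCCn1c2c(c3ccccc31)C(=O)c1c[n+]([O-])c3ccccc3c1C2=O` is not yet measured. Set against compound 1 it shows (dimethylamino in place of (4-methylpiperazin-1-yl)methyl on a saturated chain carbon, five bonds along the chain from an aromatic nitrogen). The change is the same exchange of amine as in the measured step, with the chain one bond longer. Going by the values given here, only that step from compound 1 to compound 2 bears on it, and it was modest and beyond the scatter. Among the compounds with values here, the expectation for compound 3 is therefore a number lower than compound 1 by roughly the same amount, with some allowance for the longer chain, which no measured pair addresses. The estimated step is a 5.3-fold lower number from compound 1 to compound 3 (0.72 log units; beyond the scatter). Compound 3 is expected at 550 nM, within a range from 230 nM to 1400 nM.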

Compound 3, half-maximal inhibitory concentration: 470 nM
Compound 3: middle estimate off by 1.2-fold (0.07 log units), on the high side; the measured number falls inside the stated range.
By their numbers in this assay, from the lowest: compounds 2 and 3 (each within the scatter of the next); then compound 1.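

In this assay the exchange of (4-methylpiperazin-1-yl)methyl for dimethylamino, on a saturated chain carbon five bonds along the chain from an aromatic nitrogen, gives a 6.2-fold lower number from compound 1 to compound 3 (0.79 log units; beyond the scatter) and so adds a second step in the same direction as a 6.4-fold lower number from compound 1 to compound 2 (0.81 log units; beyond the scatter) in the earlier pair. Among the compounds shown here, the new pair of dimethylamino compounds, with (dimethylamino)methyl in place of dimethylamino on a saturated chain carbon four bonds along the chain from an aromatic nitrogen, gives a 1.0-fold higher number from compound 2 to compound 3 (0.02 log units; within the scatter) and shows that this change of chain leaves the two numbers within the scatter of each other, a point no earlier pair could address. No measurement is available that would explain either of these results.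

For the compounds shown here, only two chain lengths carry the dimethylamino group here, so a clearly shorter or longer chain ending in the same group could still give a different number. Going by these compounds, whether another amine at the end of the chain, such as morpholine or pyrrolidine, would match dimethylamino or fall nearer to the 4-methylpiperazin-1-yl group also remains open.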